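A few compounds are considered here, and "the series" means these few. Any claim that something is new, unique, unknown or untested is made for them only; others in the source may bear on it.

Compound 1 `CC(=O)OC[C@H]1O[C@@H](n2c(SCc3cc4cc(Br)ccc4oc3=O)nc3cncnc32)[C@H](OC(C)=O)[C@@H]1OC(C)=O` is the starting point: in a functional assay on Huh-5-2 cells (Homo sapiens) for cytotoxicity, read by microscopy (on this read-out higher numbers stand for lower toxicity in this test and lower numbers for higher toxicity in this test), compound 1 gives 6700 nM. Compound 2 `CC(=O)OC[C@H]1O[C@@H](n2c(SCc3cc4cc(Br)cc(Br)c4oc3=O)nc3cncnc32)[C@H](OC(C)=O)[C@@H]1OC(C)=O` differs from it in a single place, (bromo in place of hydrogen on an aromatic carbon), and in this assay compound 2 gives 6000 nM; the result is a 1.1-fold lower number from compound 1 to compound 2 (0.05 log units; within the scatter). Compound 3 `CC(=O)OC[C@H]1O[C@@H](n2c(SCc3cc4cc(Br)ccc4oc3=O)nc3cncnc32)[C@H](O)[C@@H]1O` is a close relative of compound 1, but the difference between the two cores is not broken down here; in this assay compound 3 gives 31000 nM, the highest of the three numbers. Compound 4 `CC(=O)OC[C@H]1O[C@@H](n2c(SCc3cc4cc(Br)cc(Br)c4oc3=O)nc3cncnc32)[C@H](O)[C@@H]1O` stands to compound 3 exactly as compound 2 stands to compound 1, through bromo in place of hydrogen on an aromatic carbon at a place described in the same words, so it is the same change. Because a 1.1-fold lower number from compound 1 to compound 2 (0.05 log units; within the scatter) stayed within the scatter, a step of about the same small size is expected, namely a 1.1-fold lower number from compound 3 to compound 4 (0.04 log units; within the scatter). Compound 4 is therefore estimated at 28000 nM, likely between 14000 nM and 56000 nM.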

Compound 4, half-maximal cytotoxic concentration: 7000 nM
For compound 4 the middle estimate is 4.0-fold (0.60 log units) above the measured one, outside the stated range (below it).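

Putting bromo in place of hydrogen on an aromatic carbon gives a 4.4-fold lower number from compound 3 to compound 4 (0.65 log units; beyond the scatter) in this assay, so the lower number here points to higher toxicity in this test. The same change did not carry over at the same size from one core to the other: the same change on two cores in this assay, a 1.1-fold lower number (0.05 log units; within the scatter) from compound 1 to compound 2 and a 4.4-fold lower number (0.65 log units; beyond the scatter) from compound 3 to compound 4, 4.0-fold (0.60 log units) apart, beyond the scatter of two such steps. A small step on one core therefore did not foretell the step on the other, but two pairs cannot show what in the cores sets the steps apart, or what size the step would take on a further core.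

On these data alone, it remains open whether a chloro group, an amine or a carboxylic acid at this place would also give steps that differ between the two cores.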